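Removing One Methyl: Cytotoxicity Expected to Stay Silent

A few compounds are considered here, and "the series" means these few. Any claim that something is new, unique, unknown or untested is made for them only; others in the source may bear on it.

Three compounds built on a shared core were tested in an ADME assay on MDCK cells (Canis lupus familiaris) for cytotoxicity, read by CellTiter-Glo, with a stated time of 40 h; a lower number here means that less compound is tolerated, a higher number that more compound is tolerated. Compound 1 `CCCc1c(Cl)c(OC)c(Cl)c(O)c1Oc1c(Cl)c(O)c(Cl)c2c1C(=O)O[C@@H]2CC` gives > 50000 nM, which is a limit of the assay rather than a measured number. Compound 2 `CCCc1c(Cl)c(O)cc(O)c1Oc1c(Cl)c(O)c(Cl)c2c1C(=O)O[C@@H]2CC` gives > 50000 nM, again a limit. Compound 3 `CCCc1c(Cl)c(OC)cc(OC)c1Oc1c(Cl)c(O)c(Cl)c2c1C(=O)O[C@@H]2CC` gives > 50000 nM, also a limit. Among the measured compounds shown here, because every value sits at the same limit (the limit of > 50000 nM in this assay, at which 3 of the 3 values shown sit), no step between the measured compounds can be read, and compound 3 stands level with the other two at the highest point this assay reports, meaning that all of them were tolerated by the cells at every concentration tried.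

Compound 4 `CCCc1c(Cl)c(OC)cc(O)c1Oc1c(Cl)c(O)c(Cl)c2c1C(=O)O[C@@H]2CC` differs from compound 3 in one place: hydrogen in place of methyl on an oxygen on an aromatic ring. Compound 2, which carries hydrogen at both such oxygens, also sits at the limit, and compound 1 with methyl at both sits there too. The expected step in this assay is a number no higher from compound 3 to compound 4 (the limit leaves the size open), that is, none beyond the usual scatter. Compound 4 is therefore estimated at 50000 nM, within 25000 nM to 100000 nM, and most probably reported once more as a limit.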

Compound 4, half-maximal cytotoxic concentration: > 50000 nM
Compound 4: a limit, no number (the forecaster's own chance of this, stated with the estimate: 85%); the middle value lies on the limit itself.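

In this assay no step can be read between compound 4 and compound 1, compound 2 or compound 3, because all four sit at the same limit: the limit of > 50000 nM in this assay, at which 4 of the 4 values shown sit.

The compounds shown leave open where the true cytotoxic concentration of each lies, and so whether going from methoxy to hydroxy changes it at all.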